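A few compounds are considered here, and "the series" means these few. Any claim that something is new, unique, unknown or untested is made for them only; others in the source may bear on it.

Working notes on the series.

Four compounds share one core. Compound 1 `Fc1ccc(NCc2cn(-c3ccccc3)nc2-c2ccc(Cl)cc2)cc1` is the parent. Compound 2 `Cc1ccc(-c2nn(-c3ccccc3)cc2CNc2ccc(F)cc2)cc1` differs from it in one place: methyl in place of chloro on an aromatic carbon Compound 3 `Clc1ccc(NCc2cn(-c3ccccc3)nc2-c2ccc(Cl)cc2)cc1` differs from compound 1 in another place, which is how the two cores of compound 3 and compound 4 differ from those of compound 1 and compound 2: chloro in place of fluoro on an aromatic carbon Compound 4 `Cc1ccc(-c2nn(-c3ccccc3)cc2CNc2ccc(Cl)cc2)cc1` has not yet been measured.

In a functional assay on MCF7 cells (Homo sapiens) for antiproliferative activity, read by MTT assay, with a stated time of 48 h (on this read-out higher numbers stand for weaker inhibition and lower numbers for stronger inhibition), compound 1 gives 1880 nM. Compound 2 gives 5880 nM in this assay, and the step of a 3.1-fold higher number from compound 1 to compound 2 (0.50 log units; beyond the scatter) is beyond the scatter. Compound 3 gives 2280 nM in this assay; the step of a 1.2-fold higher number from compound 1 to compound 3 (0.08 log units; within the scatter) lies within the scatter, so compound 1 and compound 3 are treated as alike on this read-out.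

The change from compound 3 to compound 4 is methyl in place of chloro on an aromatic carbon This is the same change as the one from compound 1 to compound 2, made on a core that differs only as described above and that has not shifted the read-out. Among the measured compounds shown here, there is only one measured instance of this change, so the expectation rests on a single step, and on compound 3 starting from 2280 nM. The step of a 3.1-fold higher number from compound 3 to compound 4 (0.49 log units; beyond the scatter) in this assay is expected to be of about the size of a 3.1-fold higher number from compound 1 to compound 2 (0.50 log units; beyond the scatter). Compound 4 is therefore estimated at 7000 nM in this assay, with an expected range from 3500 nM to 15000 nM.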

Compound 4, half-maximal inhibitory concentration: 6020 nM
For compound 4 the middle estimate is 1.2-fold (0.07 log units) above the measured one; the range from low to high includes it.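

In this assay methyl in place of chloro on the aromatic carbon gives a 2.6-fold higher number from compound 3 to compound 4 (0.42 log units; beyond the scatter), and this step carries over from the core of compound 1 with its size intact: the same change on two cores in this assay, a 3.1-fold higher number (0.50 log units; beyond the scatter) from compound 1 to compound 2 and a 2.6-fold higher number (0.42 log units; beyond the scatter) from compound 3 to compound 4, 1.2-fold (0.07 log units) apart, within the scatter of two such steps. The second change, chloro in place of fluoro, gives a 1.0-fold higher number from compound 2 to compound 4 (0.01 log units; within the scatter), so it stays within the scatter on both cores and the two changes read here as independent of each other: the same change on two cores in this assay, a 1.2-fold higher number (0.08 log units; within the scatter) from compound 1 to compound 3 and a 1.0-fold higher number (0.01 log units; within the scatter) from compound 2 to compound 4, 1.2-fold (0.07 log units) apart, within the scatter of two such steps. This rests on a single square of four compounds whose cores differ only by chloro or fluoro in one place, so it does not show that the methyl step would hold on a core altered elsewhere, and it gives no explanation for the size of that step.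

The compounds shown carry only chloro or methyl at the place para to a large group, so it stays open whether a methoxy group, an amine, a carboxylic acid or a longer chain there would move the read-out further in either direction. From the compounds shown here alone, the rest of the shared core stays fixed throughout, and the read-out comes from one cell line, so how far the step travels beyond these four compounds also remains open.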